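From chloro to methyl on compound 2

The source may hold more compounds than are shown below. What is called first, only, known or untested is meant among the compounds shown, and "the series" means these compounds.

In a functional assay on MCF7 cells (Homo sapiens) for antiproliferative activity (on this read-out lower numbers stand for stronger inhibition and higher numbers for weaker inhibition), compound 1 `CCONC(=O)c1sc(N2N=C(c3ccc(C)cc3)CC2c2cc3cc(OC)ccc3nc2Cl)nc1C` gives 38 nM, compound 2 `COc1ccc2nc(Cl)c(C3CC(c4ccc(C)cc4)=NN3c3nc(-c4ccc(Cl)cc4)cs3)cc2c1` gives 38 nM and compound 3 `COc1ccc2nc(Cl)c(C3CC(c4ccc(C)cc4)=NN3c3nc(C)c(/N=N/c4ccccc4)s3)cc2c1` gives 38 nM, so compound 2 stands level with both others. Compound 4 `COc1ccc2nc(Cl)c(C3CC(c4ccc(C)cc4)=NN3c3nc(-c4ccc(C)cc4)cs3)cc2c1` differs from compound 2 in one place: methyl in place of chloro on an aromatic carbon. Put simply, this swap turns 4-chlorophenyl into 4-methylphenyl. Among the compounds with values here, no measured pair tests this swap directly. Two swaps of whole groups on the shared core are the nearest evidence, and they gave no change at the digits printed from compound 1 to compound 2 (within the scatter) and no change at the digits printed from compound 1 to compound 3 (within the scatter). Neither step goes beyond the scatter, so the expected step is a 1.1-fold higher number from compound 2 to compound 4 (0.02 log units; within the scatter). Compound 4 is expected near 40 nM, with an estimated range of 15 nM to 100 nM.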

Compound 4, half-maximal inhibitory concentration: 38 nM
The estimate for compound 4 lay 1.1-fold (0.02 log units) above the measured number; measured number inside the range.
By their numbers in this assay, from the lowest: compounds 1, 2, 3 and 4 (each within the scatter of the next).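

Tested directly for the first time, methyl in place of chloro on this aromatic carbon, para to a large group, gives no change at the digits printed from compound 2 to compound 4 (within the scatter) in this assay. The 4-(4-methylphenyl)-1,3-thiazol-2-yl group in place of the 5-(ethoxycarbamoyl)-4-methyl-1,3-thiazol-2-yl group gives no change at the digits printed from compound 1 to compound 4 (within the scatter), so the methyl compound matches the other two whole-group variants as well. No supporting data offer an explanation for this flat result. On these data alone, what an amine, a carboxylic acid or a longer chain would do at this same position stays open.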